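The source may report more compounds than this note shows. Statements on the series, on what has been measured and on what is new or still open speak of the compounds shown alone.

Compound 1, `Cc1ccccc1Oc1ccc(N2C[C@@H](C(F)(F)F)C[C@H]2CC(=O)O)cc1`: 73 nM
Compound 2, `Cc1ccccc1COc1ccc(N2CCC[C@H]2CC(=O)O)cc1`: 190 nM
Compound 3, `Cc1ccccc1Oc1ccc(N2CCC[C@H]2CC(=O)O)cc1`: 74 nM

Of the compounds shown here, three on a shared core have been measured in a functional assay on cells for agonist activity at Free fatty acid receptor 1 (Homo sapiens), read by FLIPR and calcium flux, with a stated time of 100 s; a higher number here means that more compound is needed for the effect, a lower number that less compound is needed. Compound 3 stands second highest of the three numbers; the nearest number is reached by the step of a 1.0-fold higher number from compound 1 to compound 3 (0.01 log units; within the scatter), and the furthest by the step of a 2.6-fold lower number from compound 2 to compound 3 (0.41 log units; beyond the scatter). Compound 4, `CCOc1ccccc1Oc1ccc(N2CCC[C@H]2CC(=O)O)cc1`, is not yet measured. It differs from compound 3 by ethoxy in place of methyl on an aromatic carbon, on an aromatic carbon of a six-membered aromatic ring of carbon only, ortho to a large group. Neither measured step touches this position: one concerns a substituent on a saturated ring carbon and lies within the scatter, the other concerns the link between the two aromatic rings and is modest. Among the compounds with values here, no measured pair shows what an ethoxy group does at this site. The expectation is therefore for a step of no more than the scatter in this assay, with no direction favoured. Compound 4 is expected to give an estimated 90 nM in this assay, within 30 nM to 300 nM, which means an estimated step of a 1.2-fold higher number from compound 3 to compound 4 (0.09 log units; within the scatter).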

Compound 4, half-maximal effective concentration: 1700 nM
Estimate against measurement, compound 4: 19-fold (1.28 log units) below; measured number outside the range, above it.
By their numbers in this assay, from the lowest: compounds 1 and 3 (each within the scatter of the next); then compound 2; then compound 4.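

In this assay, the aromatic carbon ortho to a large group proves sensitive: ethoxy in place of methyl gives a 23-fold higher number from compound 3 to compound 4 (1.36 log units; beyond the scatter), a large step. The earlier compounds shown here did not show this, as the change on the saturated ring carbon gave only a 1.0-fold higher number from compound 1 to compound 3 (0.01 log units; within the scatter), within the scatter, and the change to the link between the aromatic rings gave a modest 2.6-fold lower number from compound 2 to compound 3 (0.41 log units; beyond the scatter). Nothing measured here explains why the ethoxy compound needs so much more compound for the effect.

Going by these compounds, it remains open whether the oxygen or the longer chain of ethoxy carries this step, which an ethyl group or a methoxy group at this position would help to separate. Also open, on these data alone, is whether ethoxy would give a similar step on the trifluoromethyl-bearing core of compound 1.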